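Series notes: the step from compound 3 to compound 4

The source may report more compounds than this note shows. Statements on the series, on what has been measured and on what is new or still open speak of the compounds shown alone.

Measured so far, in a functional assay on cells (T-cell, Mus musculus, strain BALB/c) for inhibition, read by MTT assay, with a stated time of 72 h; on this read-out lower numbers stand for stronger inhibition and higher numbers for weaker inhibition:
- compound 1 `C=C(CCc1cc(O)c2c(=O)cc(-c3ccccc3)oc2c1)Cc1c(Br)cccc1C(=O)CC` gives 40700 nM
- compound 2 `COC(=O)c1cccc(OC)c1OC(=O)COc1cc(O)c2c(=O)cc(-c3ccccc3)oc2c1` gives 36800 nM
- compound 3 `COC(=O)c1cccc(C)c1OC(=O)COc1cc(O)c2c(=O)cc(-c3ccccc3)oc2c1` gives 39100 nM

All three numbers lie close together. Compound 3 stands second highest of the three, with compound 1 nearest to it and compound 2 furthest, both gaps within the scatter, so no order among the three can be claimed.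

Among the measured compounds shown here, the one step between measured compounds that differ in one place is a 1.1-fold higher number from compound 2 to compound 3 (0.03 log units; within the scatter), which lies within the scatter.

Compound 4 `COC(=O)c1cc(C)ccc1OC(=O)COc1cc(O)c2c(=O)cc(-c3ccccc3)oc2c1` is not yet measured. It differs from compound 3 as follows: a group of 11 heavy atoms (9 carbon, 2 oxygen; one six-membered aromatic ring of carbon only) in place of a group of 11 heavy atoms (9 carbon, 2 oxygen; one six-membered aromatic ring of carbon only), on an oxygen next to a carbonyl group. The two compounds have the same atoms, joined differently.

For the measured compounds named here, only the step from compound 2 to compound 3 touches the same part of the molecule, and it produced no change beyond the scatter. Going by the values given here, no measured step shows a shift of this kind, so nothing in the data points to a movement in either direction. The step is therefore expected to be a 1.0-fold lower number from compound 3 to compound 4 (0.00 log units; within the scatter), within the scatter. On that basis compound 4 is estimated at 39000 nM, with a range of 20000 nM to 80000 nM.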

Compound 4, half-maximal inhibitory concentration: 25700 nM
Beside the measured number, compound 4's estimate is 1.5-fold (0.18 log units) above it; low and high end bracket the measured number.
By their numbers in this assay, from the lowest: compounds 4, 2, 3 and 1 (each within the scatter of the next).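

In this assay, the new step is a 1.5-fold lower number from compound 3 to compound 4 (0.18 log units; within the scatter), the first one shown in which the atoms stay the same and only their joining changes, on an oxygen next to a carbonyl group. The earlier step, a 1.1-fold higher number from compound 2 to compound 3 (0.03 log units; within the scatter), replaced methoxy with methyl and so changed the atoms, whereas this one shows that a different joining of the same atoms also gives no step beyond the scatter, so both one-place steps shown for this group stay within it. No outside data bear on this result, and it can be read only as a measured step.

The compounds shown leave open whether any change to this group can produce a step beyond the scatter, for example an amine on the aromatic ring or a carboxylic acid in place of the methyl ester. They also leave open how the number responds to a one-place change on the shared core, since both readable steps touch only the group on the oxygen next to a carbonyl group.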